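Moving the acid and halogen on the phenoxy end of compound 1

This account rests on a few compounds, and the source may have more. Where it says the series, first, only, none or still open, it means among the compounds named here.

Measured compounds:
- Compound 1 `Cc1c(OCCCCOc2ccc(C(=O)O)cc2F)ccc(C(=O)CC2CCCC2)c1O`: 639 nM
- Compound 2 `Cc1c(OCCCCOc2ccc(C(=O)O)cc2F)ccc(C(=O)CC(C)C)c1O`: 102 nM
- Compound 3 `CCC(=O)c1ccc(OCCCCOc2cccc(C(=O)O)c2C)c(C)c1O`: 62 nM

All three were tested in an assay on HEK293 cells for positive allosteric modulation of metabotropic glutamate receptor 2 (Rattus norvegicus), read by thallium flux, with a stated time of 2.5 min; a lower number here means that less compound is needed, a higher number that more compound is needed for the effect. Compound 1 has the highest number of the three; compound 2 is nearest to it, with a 6.3-fold lower number from compound 1 to compound 2 (0.80 log units; beyond the scatter), and compound 3 is furthest, at 62 nM. Against that, compound 1 gives 639 nM.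

Compound 4 `Cc1c(OCCCCOc2ccc(C(=O)O)c(Cl)c2)ccc(C(=O)CC2CCCC2)c1O` has not yet been measured. It differs from compound 1 only at the far end of the four-carbon chain: 4-carboxy-3-chlorophenyl in place of 4-carboxy-2-fluorophenyl on an oxygen on a saturated carbon. The carboxylic acid and the halogen thus stand in a different pattern on that ring, and chlorine replaces fluorine.

Within the data shown here, none of the measured steps touches this part of the molecule. Among the measured compounds shown here, the only single-point step, from compound 1 to compound 2, changes the group beside the ketone, and compound 3 differs from compound 1 in several places at once. There is therefore nothing to anchor a direction for the new change, and the expectation for compound 4 in this assay is a step of about a 1.1-fold lower number from compound 1 to compound 4 (0.03 log units; within the scatter), that is, no change beyond the scatter. Compound 4 is expected to give roughly 600 nM, within a range of 200 nM to 2000 nM.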

Compound 4, half-maximal effective concentration: 510 nM
The estimate for compound 4 lay 1.2-fold (0.07 log units) above the measured number; the measured number falls inside the stated range.
By their numbers in this assay, from the lowest: compounds 3 and 2 (each within the scatter of the next); then compounds 4 and 1 (each within the scatter of the next).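

Among these compounds, this is the first step at the far end of the four-carbon chain, and in this assay putting 4-carboxy-3-chlorophenyl in place of 4-carboxy-2-fluorophenyl gives a 1.3-fold lower number from compound 1 to compound 4 (0.10 log units; within the scatter). On the core of compound 1, this ring exchange therefore stays within the scatter, whereas the change on the other side of the molecule gives a 6.3-fold lower number from compound 1 to compound 2 (0.80 log units; beyond the scatter). Nothing available explains why the two rings read so alike.

As far as these compounds go, the halogen and its place on the ring differ together, so their separate contributions remain unknown, and they could even offset each other. From the compounds shown here alone, it also remains open how a tetrazole in place of the carboxylic acid, or bromine in place of chlorine, would read, and whether the same exchange would hold with the isopropyl group of compound 2.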